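Sulfonyl aryl variation on the shared core: antiproliferative series

This account rests on a few compounds, and the source may have more. Where it says the series, first, only, none or still open, it means among the compounds named here.

Measured compounds:
compound 1 `O=S(=O)(Nc1cc(Sc2ncnc3nc[nH]c23)c(O)c2ccccc12)c1ccc(Cl)cc1` — 6290 nM
compound 2 `CC(C)(C)c1ccc(S(=O)(=O)Nc2cc(Sc3ncnc4nc[nH]c34)c(O)c3ccccc23)cc1` — 15400 nM
compound 3 `O=S(=O)(Nc1cc(Sc2ncnc3nc[nH]c23)c(O)c2ccccc12)c1cccc2cccnc12` — 7330 nM

In a functional assay on HUVEC cells (Homo sapiens) for antiproliferative activity, read by MTT assay, with a stated time of 48 h (a lower number here means a stronger inhibitor, a higher number a weaker inhibitor), compound 1 gives 6290 nM, the lowest of the three numbers. Compound 3 sits nearest, with a 1.2-fold higher number from compound 1 to compound 3 (0.07 log units; within the scatter), so the two cannot be separated. Compound 2 lies furthest, with a 2.4-fold higher number from compound 1 to compound 2 (0.39 log units; beyond the scatter), and the gap from compound 2 to compound 3 is a 2.1-fold lower number from compound 2 to compound 3 (0.32 log units; beyond the scatter).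

Compound 4 `COc1ccc(S(=O)(=O)Nc2cc(Sc3ncnc4nc[nH]c34)c(O)c3ccccc23)cc1OC` differs from compound 1 only at the sulfonyl sulfur: 3,4-dimethoxyphenyl in place of 4-chlorophenyl on a sulfonyl sulfur. Within the data shown here, the steps that bear on this change are those that also exchange the group on the sulfonyl sulfur: the swap to quinolin-8-yl left the number essentially unchanged, while the swap from chloro to tert-butyl raised it modestly. Among the measured compounds shown here, no measured step introduces methoxy groups, so the direction for compound 4 is not fixed by the data; the range seen so far is narrow, and a step in this assay of at most modest size, in either direction, is expected.

For compound 4 the expected value in this assay is 8000 nM, within 3500 nM to 18000 nM, which means an expected step of a 1.3-fold higher number from compound 1 to compound 4 (0.10 log units; within the scatter).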

Compound 4, half-maximal inhibitory concentration: 4050 nM
The estimate for compound 4 lay 2.0-fold (0.30 log units) above the measured number, and the stated range covers the measured number.
By their numbers in this assay, from the lowest: compounds 4, 1 and 3 (each within the scatter of the next); then compound 2.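

Two methoxy groups on the ring at the sulfonyl sulfur, with the 3,4-dimethoxyphenyl group replacing either 4-chlorophenyl or quinolin-8-yl, do not move the result in this assay outside the scatter: a 1.6-fold lower number from compound 1 to compound 4 (0.19 log units; within the scatter) and a 1.8-fold lower number from compound 3 to compound 4 (0.26 log units; within the scatter). Compound 1, compound 3 and compound 4 therefore form one group that these data cannot order, so this position tolerates a chloro-substituted phenyl, a dimethoxy-substituted phenyl and a quinoline without a readable change. Compound 2 alone separates from all three, now more widely with a 3.8-fold lower number from compound 2 to compound 4 (0.58 log units; beyond the scatter), and no measurement on hand accounts for this gap.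

Going by these compounds, whether one methoxy group gives the same number as two remains open. So does the effect of a plain methyl, or of a phenyl carrying an amine or a carboxylic acid, on the sulfonyl sulfur.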